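Aminoquinoline ethers: a methyl on the saturated ring

A few compounds are considered here, and "the series" means these few. Any claim that something is new, unique, unknown or untested is made for them only; others in the source may bear on it.

Measured so far:
- Compound 1 `Nc1ccc2cccc(OC3CCCCC3)c2n1`: in an assay on cells with melanin-concentrating hormone receptor 1 (Homo sapiens) as the target, read by radioligand binding (on this read-out lower numbers stand for stronger inhibition and higher numbers for weaker inhibition), compound 1 gives 361 nM.
- Compound 2 `CC1CC1COc1cccc2ccc(N)nc12`: in this assay compound 2 gives 1640 nM.
- Compound 3 `Nc1ccc2cccc(OCC3CC3)c2n1`: in this assay compound 3 reaches only > 2000 nM, which is a limit of the assay and not a number.

Compound 1 holds the lowest of the two numbers. Replacing its ring gives a 4.5-fold higher number from compound 1 to compound 2 (0.66 log units; beyond the scatter) and an at least 5.5-fold higher number from compound 1 to compound 3 (0.74 log units; beyond the scatter). Between compound 3 and compound 2 the change is methyl in place of hydrogen on a saturated ring carbon; it made an at least 1.2-fold lower number from compound 3 to compound 2 (0.08 log units; that floor lies within the scatter), and that floor rests on (the limit of > 2000 nM in this assay, at which 1 of the 3 values shown sits).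

Compound 4 `CC1CCCCC1Oc1cccc2ccc(N)nc12` is not yet measured. It differs from compound 1 by methyl in place of hydrogen on a saturated ring carbon. The two cores on which this change is made are themselves not the same: cyclohexyl in place of cyclopropylmethyl on an oxygen on an aromatic ring. The place also differs in its words, a three-membered non-aromatic ring of carbon only in the measured pair against a six-membered non-aromatic ring of carbon only here, so the change is of the same kind, not the same.

Because an at least 1.2-fold lower number from compound 3 to compound 2 (0.08 log units; that floor lies within the scatter) shows only a floor that lies within the scatter, the earlier step gives no firm direction, and a small step is expected from compound 1 to compound 4, a 1.0-fold lower number from compound 1 to compound 4 (0.01 log units; within the scatter). In this assay compound 4 is estimated at 350 nM, expected to fall between 120 nM and 1100 nM.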

Compound 4, half-maximal inhibitory concentration: 32 nM
Estimate against measurement, compound 4: 11-fold (1.04 log units) above; measured number below the stated range.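

In this assay the methyl on the six-membered ring, placed next to the ring atom that bears a large group, gives an 11-fold lower number from compound 1 to compound 4 (1.05 log units; beyond the scatter) and is therefore a large step on the core of compound 1. This firm result rests on a single pair, and it does not establish that the same change gives a step of similar size on the core with the three-membered ring, where the comparison stays unresolved: the same change on two cores in this assay, an at least 1.2-fold lower number (0.08 log units; that floor lies within the scatter) from compound 3 to compound 2 and an 11-fold lower number (1.05 log units; beyond the scatter) from compound 1 to compound 4; the limit leaves it open whether they differ. As far as these compounds go, compound 3 reads > 2000 nM as a limit of the assay and not a number, so the true size of the change on its core is unknown and the large step cannot yet be called either general or particular to the six-membered ring: the limit of > 2000 nM in this assay, at which 1 of the 4 values shown sits.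

From the compounds shown here alone, whether an ethyl group, a hydroxyl group or a fluorine in the place of the methyl on the six-membered ring would keep this step stays open. Equally open, going by these compounds, is whether the step would carry over if an amine link stood in place of the ether oxygen on the shared core.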